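Cyano for amino on the triazine of compound 2

The source may hold more compounds than are shown below. What is called first, only, known or untested is meant among the compounds shown, and "the series" means these compounds.

Compound 1, `CNc1nc(NC2(C#N)CCCCC2)nc(-n2ccnc2)n1`, in an in vitro assay on Sf21 cells for inhibition of high affinity 3',5'-cyclic-AMP phosphodiesterase 7A (Homo sapiens); on this read-out lower numbers stand for stronger inhibition and higher numbers for weaker inhibition: 1050 nM.
Compound 2, `CNc1nc(N)nc(NC2(C#N)CCCCC2)n1`, in this assay: "not determined" (no result reported).

Compound 2 therefore stands on no number at all in this assay; only compound 1 has a measured value there. Compound 3, `CNc1nc(C#N)nc(NC2(C#N)CCCCC2)n1`, differs from compound 2 by cyano in place of amino on an aromatic carbon. Going by the values given here, with no measured pair of this kind and no value for compound 2, there is no basis for expecting a step in either direction beyond the usual scatter. Compound 3 is estimated at 900 nM, with a plausible range from 150 nM to 5000 nM.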

Compound 3, half-maximal inhibitory concentration: > 1000 nM
Compound 3 was reported as a limit; the forecaster's own chance of this, stated with the estimate: 20%; middle value at least 1.1-fold (0.04 log units) away from the limit.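

In this assay, going by these compounds alone, compound 3 gives > 1000 nM as a limit and not a number, so no step to compound 1 or compound 2 can be read. From the compounds shown here alone, whether cyano in place of amino or 1H-imidazol-1-yl on that aromatic carbon strengthens or weakens inhibition stays open.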